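A few compounds are considered here, and "the series" means these few. Any claim that something is new, unique, unknown or untested is made for them only; others in the source may bear on it.

In an ADME assay on MT4 cells (Homo sapiens) for cytotoxicity (a higher number here means that more compound is tolerated, a lower number that less compound is tolerated), compound 1 `COc1ccc(C(=O)CSc2nc(Cc3ccccc3Br)c(C)c(=O)[nH]2)cc1` gives > 272000 nM, which is a limit of the assay and not a number.
In this assay compound 2 `COc1ccc(C(=O)CSc2nc(Cc3cccc(Br)c3)c(C)c(=O)[nH]2)cc1` gives >= 196000 nM, again a limit of the assay.
In this assay compound 3 `COc1ccc(C(=O)CSc2nc(Cc3ccc(Br)cc3)c(C)c(=O)[nH]2)cc1` gives > 272000 nM, also a limit of the assay.

For the measured compounds named here, compound 3 therefore stands where the other two measured compounds stand: every value so far is a limit, so none of the three can be ranked against another. The steps between them, a step that the two limits leave unreadable from compound 1 to compound 2, a step that the two limits leave unreadable from compound 1 to compound 3 and a step that the two limits leave unreadable from compound 2 to compound 3, cannot be given a size for the same reason. What the numbers do show is the limit of > 272000 nM in this assay, at which 2 of the 3 values shown sit, and (the limit of >= 196000 nM in this assay, at which 1 of the 3 values shown sits).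

Compound 4 `COc1ccc(C(=O)CSc2nc(Cc3cc(C)cc(C)c3)c(C)c(=O)[nH]2)cc1` differs from compound 3 by 3,5-dimethylphenyl in place of 4-bromophenyl on a saturated chain carbon bound to an aromatic carbon. The three measured steps all exchange one bromophenyl for another on that same saturated chain carbon, so they bear directly on this change, yet none of them is readable. With every measured compound tolerated up to the limit, the expectation for compound 4 in this assay is a step of a number no higher from compound 3 to compound 4 (the limit leaves the size open), that is, nothing beyond the usual scatter. Compound 4 is estimated at 272000 nM, within a range from 120000 nM to 400000 nM, most likely again reported only as a limit.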

Compound 4, half-maximal cytotoxic concentration: > 308000 nM
Compound 4: only a limit was reported (the forecaster's own chance of this, stated with the estimate: 80%); middle value at least 1.1-fold (0.05 log units) away from the limit.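

In this assay compound 4 gives > 308000 nM, which is a limit of the assay and not a number. For the compounds shown here, compound 1, compound 2 and compound 3 also gave only limits, and no step from any of them to compound 4 can be read. The compounds shown leave open what concentration of each is actually cytotoxic, and whether 3,5-dimethylphenyl in place of a bromophenyl changes it.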